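Pyrimidine to pyridine on the aminomethyl arm

A few compounds are considered here, and "the series" means these few. Any claim that something is new, unique, unknown or untested is made for them only; others in the source may bear on it.

The series keeps the core shown in compound 2 `Cc1nc(C(=O)N2CC3(CC3)C[C@H]2CNc2ncc(Cl)cn2)c(-c2ccccc2)s1` and varies the aromatic group on the amine nitrogen. In a functional assay on HEK293 cells for antagonist activity at Orexin receptor type 2 (Homo sapiens), read by FLIPR and calcium flux (a lower number here means a less potent compound, a higher number a more potent compound, by a factor of ten per unit of this negative logarithm), compound 2 gives 6.8, the lower of the two numbers in hand; compound 1 `Cc1cccc(NC[C@@H]2CC3(CC3)CN2C(=O)c2nc(C)sc2-c2ccccc2)n1` gives 7.6. Among the compounds with values here, the single measured step, a number 0.80 log units lower from compound 1 to compound 2 (beyond the scatter), exchanges ring type and substituent at once, so it bears only in part on the next change. Compound 3 `Cc1nc(C(=O)N2CC3(CC3)C[C@H]2CNc2ccc(Cl)cn2)c(-c2ccccc2)s1` derives from compound 2 by 5-chloropyridin-2-yl in place of 5-chloropyrimidin-2-yl on an amine nitrogen. Compound 3 therefore carries the ring class of compound 1 together with the chlorine of compound 2. The downward step seen on going to compound 2 is partly reversed here, so an upward move, short of a full return, is expected for compound 3: a number 0.50 log units higher from compound 2 to compound 3 (beyond the scatter). The estimate for compound 3 is 7.3, with a range from 6.7 to 7.9.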

Compound 3, negative logarithm of the antagonist equilibrium constant: 7.1
Compound 3: the middle estimate sits 0.20 log units above what was measured; low and high end bracket the measured number.
By their numbers in this assay, from the lowest: compounds 2 and 3 (each within the scatter of the next); then compound 1.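

With the chlorine held, 5-chloropyridin-2-yl in place of 5-chloropyrimidin-2-yl on the amine nitrogen gives a number 0.30 log units higher from compound 2 to compound 3 (within the scatter) in this assay, so the ring with 1 hetero atom and the ring with 2 hetero atoms are not separated at this position. With the pyridine class held, 5-chloropyridin-2-yl in place of 6-methylpyridin-2-yl gives a number 0.50 log units lower from compound 1 to compound 3 (beyond the scatter), so a step beyond the scatter remains when only the ring substituent and its place differ. The data available give no reason for either step.

Still open, from the compounds shown here alone, is whether the identity of the substituent or its place on the ring accounts for that remaining step. A 6-chloropyridin-2-yl or a 5-methylpyridin-2-yl group on the amine nitrogen would separate the two, and an unsubstituted pyridin-2-yl group would show what either substituent contributes.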